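A few compounds are considered here, and "the series" means these few. Any claim that something is new, unique, unknown or untested is made for them only; others in the source may bear on it.

The measured compounds:

Compound 1, `CC1=NC(C)=C(C(=O)OCCCN2C(=O)c3ccccc3S2(=O)=O)C(c2ccccc2C(F)(F)F)/C1=C(\O)OC(C)C`, gives 2.7 nM in a functional assay (aorta) with Oryctolagus cuniculus as the target; a higher number here means a weaker inhibitor, a lower number a stronger inhibitor.
Compound 2, `COCCO/C(O)=C1\C(C)=NC(C)=C(C(=O)OCCCN2C(=O)c3ccccc3S2(=O)=O)C1c1ccccc1C(F)(F)F`, gives 1.4 nM in this assay.
Compound 3, `CC1=NC(C)=C(C(=O)OCCCN2C(=O)c3ccccc3S2(=O)=O)C(c2ccccc2Cl)/C1=C(\O)OC(C)C`, gives 1.3 nM in this assay.

Compound 2 differs from compound 1 by 2-methoxyethyl in place of isopropyl on an oxygen on an unsaturated carbon, and this change made a step of a 1.9-fold lower number from compound 1 to compound 2 (0.29 log units; within the scatter). Compound 3 differs from compound 1 by chloro in place of trifluoromethyl on an aromatic carbon, which made a step of a 2.1-fold lower number from compound 1 to compound 3 (0.32 log units; beyond the scatter). The values of compound 2 and compound 3 lie within the scatter of each other, so nothing separates those two in this assay.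

Compound 4, `COCCO/C(O)=C1\C(C)=NC(C)=C(C(=O)OCCCN2C(=O)c3ccccc3S2(=O)=O)C1c1ccccc1Cl`, has not yet been measured. It differs from compound 3 by 2-methoxyethyl in place of isopropyl on an oxygen on an unsaturated carbon. This is the same change that turns compound 1 into compound 2, and the place where it is made is described in the same words for both pairs. The two cores on which it is made differ from each other by chloro in place of trifluoromethyl on an aromatic carbon, the difference between compound 1 and compound 3.

Going by the values given here, since the one earlier instance of this change, from compound 1 to compound 2, produced a step that stays within the scatter, compound 4 is expected to follow compound 3 with a step of about a 1.3-fold lower number from compound 3 to compound 4 (0.11 log units; within the scatter), resting on that single precedent and on the value of compound 3, 1.3 nM. On that basis compound 4 is estimated to give 1 nM in this assay, with an expected range from 0.5 nM to 2.2 nM.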

Compound 4, half-maximal inhibitory concentration: 2.9 nM
Estimate against measurement, compound 4: 2.9-fold (0.46 log units) below; the whole stated range lies below it.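

On the core carrying chloro, 2-methoxyethyl in place of isopropyl gave a 2.2-fold higher number from compound 3 to compound 4 (0.35 log units; beyond the scatter), and this step does not match the one seen on the core carrying trifluoromethyl: the same change on two cores in this assay, a 1.9-fold lower number (0.29 log units; within the scatter) from compound 1 to compound 2 and a 2.2-fold higher number (0.35 log units; beyond the scatter) from compound 3 to compound 4, 4.3-fold (0.63 log units) apart, beyond the scatter of two such steps Read the other way, chloro in place of trifluoromethyl gave a 2.1-fold higher number from compound 2 to compound 4 (0.32 log units; beyond the scatter) with 2-methoxyethyl present, which also fails to match the step seen with isopropyl present: the same change on two cores in this assay, a 2.1-fold lower number (0.32 log units; beyond the scatter) from compound 1 to compound 3 and a 2.1-fold higher number (0.32 log units; beyond the scatter) from compound 2 to compound 4, 4.3-fold (0.63 log units) apart, beyond the scatter of two such steps In this assay, then, neither change can be carried from one core to the other as a fixed step among these four compounds, although this rests on a single set of four, each step beyond the scatter is only modest, and the data do not show what produces the difference between the cores.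

The compounds shown leave open how a longer ether chain or a chain ending in an amine would behave in place of isopropyl, and whether bromo or a nitrile on the aromatic carbon would follow chloro or trifluoromethyl. They also leave open whether the same dependence on the core would appear in any read-out other than this assay.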